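Amine swap at the chain terminus of compound 1

A few compounds are considered here, and "the series" means these few. Any claim that something is new, unique, unknown or untested is made for them only; others in the source may bear on it.

Compound 1 `N#Cc1cccc([C@]23CCC(N(CCN4CC[C@@H](O)C4)C(=O)Nc4cc(F)cc(F)c4)CC2C3)c1` is measured in a functional assay for antagonist activity at melanin-concentrating hormone receptor 1 (Homo sapiens) (a higher number here means a weaker inhibitor, a lower number a stronger inhibitor), at 15 nM and stands second highest of the three numbers in hand. Going by the values given here, compound 3 `CC(C)N(CCN(C(=O)Nc1ccc(F)c(Cl)c1)C1CC[C@]2(c3cccc(C#N)c3)CC2C1)C(C)C` gives 4.98 nM in this assay, a value beyond the scatter below compound 1; compound 2 `N#Cc1cccc(NC(=O)N(CCN2CC[C@@H](O)C2)C2CC[C@]3(c4cccc(C#N)c4)CC3C2)c1` gives 92 nM, and the only single-site step in the set, a 6.1-fold higher number from compound 1 to compound 2 (0.79 log units; beyond the scatter), concerns the aryl group on the urea nitrogen, not the chain terminus.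

Compound 4 `CC(C)N(CCN(C(=O)Nc1cc(F)cc(F)c1)C1CC[C@]2(c3cccc(C#N)c3)CC2C1)C(C)C` differs from compound 1 by diisopropylamino in place of 3-hydroxypyrrolidin-1-yl on a saturated chain carbon, two bonds along the chain from an amide-type nitrogen. Among the compounds with values here, no measured pair isolates this change. Compound 3 carries the same diisopropylamino terminus but also a different aryl group, so its value bears on compound 4 only indirectly; it does show that the diisopropylamino chain is compatible with a low number. The expectation for compound 4 is therefore a modest downward step or none beyond the scatter, a 1.9-fold lower number from compound 1 to compound 4 (0.27 log units; within the scatter). Compound 4 is estimated in this assay at 8 nM, within a range of 2.5 nM to 25 nM.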

Compound 4, inhibition constant: 4.5 nM
Compound 4: the middle estimate sits 1.8-fold (0.25 log units) above what was measured; measured number inside the range.
By their numbers in this assay, from the lowest: compounds 4 and 3 (each within the scatter of the next); then compound 1; then compound 2.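

Going by these compounds alone, the first matched pair for this change shows that the chain terminus is not silent in this assay (a 3.3-fold lower number from compound 1 to compound 4 (0.52 log units; beyond the scatter)): with the 3,5-difluorophenyl group and the core held, diisopropylamino, with no ring, stereocentre or hydrogen-bond donor, gives the lower number. With diisopropylamino held, 3,5-difluorophenyl and 3-chloro-4-fluorophenyl on the amide-type nitrogen are not told apart (a 1.1-fold lower number from compound 3 to compound 4 (0.04 log units; within the scatter)). Nothing available speaks to the cause of the terminus step.

The compounds shown leave open whether that step follows the hydroxyl, the ring or the isopropyl groups; an unsubstituted pyrrolidin-1-yl or a diethylamino terminus would separate these. Also open, as far as these compounds go, is whether the step carries over to the 3-cyanophenyl urea of compound 2, seen here only with 3-hydroxypyrrolidin-1-yl.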